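Pyrazolyl Ureas Against a STE20-like Kinase: Melting Shift

The source may hold more compounds than are shown below. What is called first, only, known or untested is meant among the compounds shown, and "the series" means these compounds.

Measured compounds and values:
Compound 1, `CC(C)(C)c1cc(NC(=O)Nc2cc(C(F)(F)F)cc(C(F)(F)F)c2)n(C(C)(C)C)n1`: -0.2 degrees C
Compound 2, `CC(C)(C)c1cc(NC(=O)Nc2cc(C(F)(F)F)cc(C(F)(F)F)c2)n(-c2ccc(Br)cc2)n1`: 0.1 degrees C
Compound 3, `CC(C)(C)c1cc(NC(=O)Nc2cc(F)cc(F)c2)n(C(C)(C)C)n1`: 0.2 degrees C

In an assay on isolated protein for inhibition of STE20-like serine/threonine-protein kinase (Homo sapiens), read by thermal shift assay, tested at 10 uM (on this read-out lower numbers stand for weaker stabilisation of the target and higher numbers for stronger stabilisation of the target against heat), compound 1 gives -0.2 degrees C. Compound 2 is its partner with 4-bromophenyl in place of tert-butyl on an aromatic nitrogen, and the step is a number 0.30 degrees C higher from compound 1 to compound 2 (within the scatter). Compound 3 gives 0.2 degrees C in this assay; the difference between the core of compound 3 and the core of compound 1 is not broken down here. The three values lie within the scatter of one another, so none stands apart.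

Compound 4, `CC(C)(C)c1cc(NC(=O)Nc2cc(F)cc(F)c2)n(-c2ccc(Br)cc2)n1`, has not yet been measured in this assay. It carries the same change as compound 2, namely (4-bromophenyl in place of tert-butyl on an aromatic nitrogen). Since the earlier step was a number 0.30 degrees C higher from compound 1 to compound 2 (within the scatter), a step of about a number 0.20 degrees C higher from compound 3 to compound 4 (within the scatter) is expected here, resting only on that one pair. Compound 4 is therefore estimated at 0.4 degrees C, between -0.6 degrees C and 1.4 degrees C.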

Compound 4, shift of the target's melting temperature: 0.5 degrees C
Compound 4: the middle estimate sits 0.10 degrees C below what was measured; measured number inside the range.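

In this assay, 4-bromophenyl in place of tert-butyl on an aromatic nitrogen gives a number 0.30 degrees C higher from compound 3 to compound 4 (within the scatter). Set beside the earlier step, the change reads alike on the two cores: the same change on two cores in this assay, a number 0.30 degrees C higher (within the scatter) from compound 1 to compound 2 and a number 0.30 degrees C higher (within the scatter) from compound 3 to compound 4, 0.000000000000000056 degrees C apart, within the scatter of two such steps.
For the compounds shown here, this agreement shows only that the change leaves the read-out within the scatter on both cores, not that it raises stabilisation of the target. Two small steps also cannot show how the change would carry over to any other core in the series.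

From the compounds shown here alone, what an amine or a carboxylic acid on that nitrogen would give in this assay stays open. So does whether any compound in this series can move the melting temperature beyond the scatter.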